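Swapping a Fluorobenzyl Arm for a Hydroxyethyl Chain

The source may report more compounds than this note shows. Statements on the series, on what has been measured and on what is new or still open speak of the compounds shown alone.

Compound 1 `CS(=O)(=O)Oc1c(C(=O)NCc2ccc(F)cc2)nc(Br)c2cccnc12` was tested in a toxicity assay on C8166 cells (Homo sapiens) for cytotoxicity, read by MTT assay, with a stated time of 72 h (a lower number here means that less compound is tolerated, a higher number that more compound is tolerated), where compound 1 gives 48000 nM. Compound 2 `O=C(NCc1ccc(F)cc1)c1nc(Br)c2cccnc2c1NCc1ccc(F)cc1` shares the core of compound 1 but places a (4-fluorobenzyl)amino group where compound 1 carries a sulfonate ester; for compound 2 the outcome in this assay is "not determined" (no result reported), so compound 2 stands on no number at all, and nothing can be said about how compound 1 and compound 2 compare. Compound 3 `O=C(NCc1ccc(F)cc1)c1nc(Br)c2cccnc2c1NCCO` is compound 2 with one change: hydroxymethyl in place of 4-fluorophenyl on a saturated chain carbon bound to a nitrogen on an aromatic ring. Going by the values given here, with no measured neighbour for compound 3 and no number for compound 2, no step can be sized here; the only anchor in this assay is the value of compound 1, and compound 3 is expected to land in a similar region, with a wide range. Compound 3 is estimated to give 60000 nM in this assay, with a plausible span from 20000 nM to 200000 nM.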

Compound 3, half-maximal cytotoxic concentration: 232000 nM
Compound 3: the middle estimate sits 3.9-fold (0.59 log units) below what was measured; the whole stated range lies below it.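

At this position on the shared core, this assay now gives a first measured comparison: (2-hydroxyethyl)amino in place of (methylsulfonyl)oxy produces a 4.8-fold higher number from compound 1 to compound 3 (0.68 log units; beyond the scatter), a modest step beyond the usual scatter, so more compound is tolerated. The step from compound 2 to compound 3 cannot be read, as compound 2 has no number, so the swap from 4-fluorobenzyl to 2-hydroxyethyl has no size of its own. Nothing available accounts for the rise seen with the new group.

Whether the hydroxyl group at the end of the chain matters stays open, since a plain ethylamino group is not among the compounds shown. A longer chain ending in hydroxyl, or a simple amine at this position, could also show whether the number keeps climbing.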